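Shared core series: notes on the aryl substituent step

A few compounds are considered here, and "the series" means these few. Any claim that something is new, unique, unknown or untested is made for them only; others in the source may bear on it.

Measured in a functional assay on 786-0 cells (Homo sapiens) for inhibition, read by sulforhodamine B assay, with a stated time of 48 h; on this read-out lower numbers stand for stronger inhibition of growth and higher numbers for weaker inhibition of growth:
compound 1 `O=C1C=COC(/C=C/c2ccccc2)C1` gives 138 uM
compound 2 `O=C1C=COC(/C=C/c2ccc(C(F)(F)F)cc2)C1` gives 39.6 uM

Compound 2 holds the lowest of the two numbers; its nearest neighbour is compound 1, which gives a higher number, the step between them being a 3.5-fold lower number from compound 1 to compound 2 (0.54 log units; beyond the scatter). Compound 3 `COc1ccc(/C=C/C2CC(=O)C=CO2)cc1` has not been measured. It differs from compound 2 by methoxy in place of trifluoromethyl on an aromatic carbon.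

Within the data shown here, the only measured step that bears on this change is the one from compound 1 to compound 2, in which trifluoromethyl entered on the same aromatic carbon with a modest lowering of the number. Among the measured compounds shown here, no measured step shows methoxy entering anywhere, and none shows trifluoromethyl leaving. The present change takes away the group that arrived in that step and brings in a different one, so its effect is uncertain; compound 3 is expected to land between the two measured numbers, with a step from compound 2 of about a 2.0-fold higher number from compound 2 to compound 3 (0.31 log units; beyond the scatter) toward a higher number. In this assay the estimate for compound 3 is 80 uM, with a range from 30 uM to 200 uM.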

Compound 3, concentration for growth inhibition (reported as GI): 192 uM
Beside the measured number, compound 3's estimate is 2.4-fold (0.38 log units) below it; measured number inside the range.
By their numbers in this assay, from the lowest: compound 2; then compounds 1 and 3 (each within the scatter of the next).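

In this assay, the lower number that came with trifluoromethyl does not carry over to methoxy on the same aromatic carbon (a 4.8-fold higher number from compound 2 to compound 3 (0.69 log units; beyond the scatter)), so this position responds to the identity of the group and not merely to the replacement of hydrogen. The methoxy compound also gives the first direct reading against the unsubstituted compound (a 1.4-fold higher number from compound 1 to compound 3 (0.14 log units; within the scatter)): that step lies within the scatter, so compound 3 cannot be told apart from compound 1, and among the groups shown only trifluoromethyl separates from hydrogen on this read-out. No measurement at hand accounts for the difference between trifluoromethyl and methoxy here, and the numbers alone record the difference without explaining it.

From the compounds shown here alone, with only hydrogen, trifluoromethyl and methoxy in view, it remains open whether a nitrile, a halogen, an amine or a carboxylic acid on this carbon would follow trifluoromethyl or stay with methoxy and hydrogen. Going by these compounds, it is equally open whether trifluoromethyl would give a similar step on another carbon of the aromatic ring, or whether the step seen here belongs to this place alone.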